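Amide aryl to benzyl exchange and compound tolerance

The compounds below may be only part of what the source reports. "The series", "measured", "known", "first", "only" and "open" are said of these compounds alone.

Working notes on a small series built on the shared core of compound 1 `O=C(CCSc1nnc(-c2ccncc2)s1)Nc1c(Cl)cccc1Cl`. In an ADME assay on HepG2 cells (Homo sapiens) for cytotoxicity, with a stated time of 3 days (a higher number here means that more compound is tolerated, a lower number that less compound is tolerated), compound 1 gives 12600 nM. Compound 2 `O=C(CCSc1nnc(-c2ccncc2)s1)Nc1ccc(Cl)cc1Cl` sits at a boundary of the same measurement: in this assay compound 2 gives > 50000 nM, which is a limit of the assay rather than a number. Going by the values given here, the only measured step is an at least 3.9-fold higher number from compound 1 to compound 2 (0.59 log units; beyond the scatter); it runs into (the limit of > 50000 nM in this assay, at which 1 of the 2 values shown sits), so its full size is not known, and compound 2 stands at that limit with nothing more precise.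

Compound 3 `O=C(CCSc1nnc(-c2ccncc2)s1)NCc1ccccc1Cl` differs from compound 2 by 2-chlorobenzyl in place of 2,4-dichlorophenyl on an amide-type nitrogen. Among the compounds with values here, no measured step covers an exchange of an aryl group for a benzyl group on the amide nitrogen; the single step seen concerns only the placement of ring chlorines and was at least modest in the direction of more compound tolerated. On that thin basis no step beyond the scatter in this assay is expected in either direction from compound 2 to compound 3, with a real chance that compound 3 again returns only the limit. Compound 3 is estimated at 40000 nM, within 15000 nM to 100000 nM. The expected step is an at least 1.2-fold lower number from compound 2 to compound 3 (0.09 log units; that floor lies within the scatter).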

Compound 3, half-maximal cytotoxic concentration: > 50000 nM
Compound 3: no number, only a limit; the forecaster's own chance of this, stated with the estimate: 55%; middle value at least 1.2-fold (0.09 log units) from the limit.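

In this assay compound 3 gives > 50000 nM, which is a limit of the assay and not a number. On the amide-type nitrogen, 2-chlorobenzyl in place of 2,6-dichlorophenyl gives an at least 3.9-fold higher number from compound 1 to compound 3 (0.59 log units; beyond the scatter), so a benzyl-type group, and not only the 2,4-dichlorophenyl of compound 2, also stands clear of compound 1 in the direction of more compound tolerated. Compound 2 and compound 3 both end at the limit, and the step between them cannot be read: the limit of > 50000 nM in this assay, at which 2 of the 3 values shown sit.

On these data alone, how far past the limit compound 2 and compound 3 lie stays open, so no order between the aryl and benzyl groups on this nitrogen can be given, and the lower number of compound 1 remains the only one that can be placed on the scale. Also open, as far as these compounds go, is whether a 2,6-dichlorobenzyl group, which carries the chlorine pattern of compound 1 on a benzyl group, or a group of another kind on this nitrogen, such as a cyclohexyl or a benzyl bearing a carboxylic acid, would return a number rather than the limit.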